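A few compounds are considered here, and "the series" means these few. Any claim that something is new, unique, unknown or untested is made for them only; others in the source may bear on it.

Compound 1, `CS/C(=N\C(=O)c1csc([N+](=O)[O-])c1)NC(=O)c1csc([N+](=O)[O-])c1`, gives 1550 nM in an ADME assay on MCF-10A cells (Homo sapiens) for cytotoxicity, read by MTT assay, with a stated time of 72 h; a higher number here means a weaker inhibitor of growth, a lower number a stronger inhibitor of growth.
Compound 2, `CS/C(=N\C(=O)c1ccno1)NC(=O)c1ccno1`, gives 16900 nM in this assay.
Compound 3, `O=C(/N=C(/NC(=O)c1csc([N+](=O)[O-])c1)[Se]Cc1ccccc1)c1csc([N+](=O)[O-])c1`, gives 24400 nM in this assay.

Compound 3 stands at the highest of the three numbers in this assay. Its value and that of compound 2 lie within the scatter of each other, while compound 1 sits far lower: a 16-fold higher number from compound 1 to compound 3 (1.20 log units; beyond the scatter). Among the measured compounds shown here, that is the only measured step bearing on the next move. Compound 4, `C[Se]/C(=N\C(=O)c1csc([N+](=O)[O-])c1)NC(=O)c1csc([N+](=O)[O-])c1`, differs from compound 3 by hydrogen in place of phenyl on a saturated chain carbon bound to a selenium atom. For the measured compounds named here, compound 4 thus carries the methyl group of compound 1 on its chain, with selenium in place of the sulfur of compound 1; for that selenium-sulfur exchange alone no measured step exists here. The step from compound 1 to compound 3 combined the enlargement of the group on this carbon with the exchange of sulfur for selenium, and trimming back to methyl is expected to reverse much, though not necessarily all, of that rise. Compound 4 is expected to show a large fall in number, an 8.1-fold lower number from compound 3 to compound 4 (0.91 log units; beyond the scatter), toward compound 1. The estimated value of compound 4 in this assay is 3000 nM, with a range from 1000 nM to 10000 nM.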

Compound 4, concentration for 50% growth inhibition: 1950 nM
Compound 4: middle estimate off by 1.5-fold (0.19 log units), on the high side, and the stated range covers the measured number.
By their numbers in this assay, from the lowest: compounds 1 and 4 (each within the scatter of the next); then compounds 2 and 3 (each within the scatter of the next).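

In this assay, trimming benzyl to methyl on the saturated chain carbon bound to a selenium atom gives a 13-fold lower number from compound 3 to compound 4 (1.10 log units; beyond the scatter) with selenium held in place, so the group on selenium alone can move the number this far. Exchanging sulfur for selenium with methyl kept gives a 1.3-fold higher number from compound 1 to compound 4 (0.10 log units; within the scatter) and thus no change beyond the scatter, which places the large step seen earlier, a 16-fold higher number from compound 1 to compound 3 (1.20 log units; beyond the scatter) on the benzyl group rather than on the change of atom. No measured evidence here explains either step.

Going by these compounds, it remains open whether the aromatic ring of benzyl or the chain length drives the rise, which an ethyl group, a longer chain or a chain ending in an amine on selenium could separate. On these data alone, it also remains open whether benzyl on the core of compound 2 would behave in the same way.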